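Swapping methoxy for chloro on the benzyl ring: cytotoxicity outlook

This account rests on a few compounds, and the source may have more. Where it says the series, first, only, none or still open, it means among the compounds named here.

Of the compounds shown here, three sharing one core have been tested in an ADME assay on MRC5 cells (Homo sapiens) for cytotoxicity; on this read-out higher numbers stand for weaker inhibition and lower numbers for stronger inhibition. Compound 1 `COc1ccc(Cn2cc(CNC(=O)c3ccc([N+](=O)[O-])o3)nn2)cc1[N+](=O)[O-]` gives 198000 nM. Compound 2 `COc1cc(Cn2cc(CNC(=O)c3ccc([N+](=O)[O-])o3)nn2)ccc1F` gives 155000 nM in this assay, the lowest of the three numbers, though its gap to compound 1 lies within the scatter, so the two cannot be ranked against each other. Compound 3 `O=C(NCc1cn(Cc2ccc(C(F)(F)F)cc2)nn1)c1ccc([N+](=O)[O-])o1` gives 321000 nM in this assay, a higher number than compound 2 by a margin beyond the scatter.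

The step now followed leads from compound 2 to compound 4 `O=C(NCc1cn(Cc2ccc(F)c(Cl)c2)nn1)c1ccc([N+](=O)[O-])o1`, which is yet to be measured in this assay. The change is chloro in place of methoxy on an aromatic carbon. For the measured compounds named here, no pair of measured compounds differs in this way, so nothing measured tells directly what it does here.

All three measured numbers sit in a narrow band of weak cytotoxicity, and compound 3, which carries a different substituted benzyl group, gives 321000 nM, not far from the others. The expectation is therefore a small step of a 1.3-fold higher number from compound 2 to compound 4 (0.11 log units; within the scatter), if any, probably toward a slightly higher number, not reliably beyond the scatter. Compound 4 is estimated at 200000 nM, with a range from 100000 nM to 400000 nM.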

Compound 4, half-maximal inhibitory concentration: 254000 nM
Beside the measured number, compound 4's estimate is 1.3-fold (0.10 log units) below it; the range from low to high includes it.
By their numbers in this assay, from the lowest: compounds 2, 1, 4 and 3 (each within the scatter of the next, the first and the last beyond it).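

Chloro in place of methoxy, which turns the 4-fluoro-3-methoxyphenyl group into the 3-chloro-4-fluorophenyl group, is the first single-place change that can be read in this assay, and it gives a 1.6-fold higher number from compound 2 to compound 4 (0.21 log units; within the scatter). At this position, on an aromatic carbon ortho to a fluoro group and meta to a large group, a single chlorine can therefore stand where the methoxy with its hydrogen-bond acceptor stood, and compound 2 and compound 4 cannot be ranked against each other. No measurement at hand offers a reason for this outcome.

As far as these compounds go, whether a group of another kind at this position, such as an amine, a carboxylic acid or a longer chain like ethoxy, would give a step beyond the scatter remains open. For the compounds shown here, it is also open whether chloro in place of methoxy would read the same way on a benzyl ring that lacks the fluoro group, as this single pair is the only evidence for the change.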